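The source may hold more compounds than are shown below. What is called first, only, known or untested is meant among the compounds shown, and "the series" means these compounds.

Measured so far in a functional assay on A549 cells (Homo sapiens) for antiproliferative activity, read by MTT assay, with a stated time of 48 h; a higher number here means a weaker inhibitor, a lower number a stronger inhibitor:

- compound 1, `C#Cc1cccc(Nc2ncnc3cc(NC(=O)/C=C/c4ccccc4)sc23)c1`: 26200 nM
- compound 2, `O=C(/C=C/c1ccccc1)Nc1cc2ncnc(Nc3cc(Cl)cc(Cl)c3)c2s1`: 12500 nM
- compound 3, `C#Cc1cccc(Nc2ncnc3sc(NC(=O)/C=C/c4ccccc4)cc23)c1`: 10100 nM

Compound 1 and compound 2 share a core and differ in one place: 3,5-dichlorophenyl in place of 3-ethynylphenyl on a nitrogen on an aromatic ring. The step is a 2.1-fold lower number from compound 1 to compound 2 (0.32 log units; beyond the scatter), a modest gain that nonetheless lies beyond the scatter.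

Compound 3 is built from the same atoms as compound 1, joined differently; the difference between the two cores is not broken down here. Compound 3 gives the lowest number of the three measured, but its gap to compound 2 is within the scatter, so no order between those two is claimed. Only its gap to compound 1 is beyond the scatter.

Compound 4, `O=C(/C=C/c1ccccc1)Nc1cc2c(Nc3cc(Cl)cc(Cl)c3)ncnc2s1`, has not yet been measured in this assay. Relative to compound 3 it carries the same change already seen between compound 1 and compound 2: 3,5-dichlorophenyl in place of 3-ethynylphenyl on a nitrogen on an aromatic ring. Both changes sit at a place described in the same words, a nitrogen on an aromatic ring whose other neighbours are aromatic carbon, so this is the same change, carried on the core of compound 3 rather than the core of compound 1.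

Among the measured compounds shown here, with only one earlier instance of this change, the expectation rests on that instance alone: a step of the same direction and similar size is expected for compound 4, namely a 1.8-fold lower number from compound 3 to compound 4 (0.26 log units; within the scatter), because compound 1 to compound 2 showed a 2.1-fold lower number from compound 1 to compound 2 (0.32 log units; beyond the scatter). From the compounds shown here alone, whether the rearranged core of compound 3 answers the change in the same way is untested, so the range is kept wide. The estimate for compound 4 in this assay is 5500 nM, between 2500 nM and 12000 nM.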

Compound 4, half-maximal inhibitory concentration: 40 nM
The estimate for compound 4 lay 140-fold (2.14 log units) above the measured number; the whole stated range lies above it.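

In this assay, 3,5-dichlorophenyl in place of 3-ethynylphenyl on a nitrogen on an aromatic ring gives a 250-fold lower number from compound 3 to compound 4 (2.40 log units; beyond the scatter), a large step on the core of compound 3. The direction of the change holds on both cores, but its size does not carry over, so the step seen on one core is a poor guide to the size of the step on the other: the same change on two cores in this assay, a 2.1-fold lower number (0.32 log units; beyond the scatter) from compound 1 to compound 2 and a 250-fold lower number (2.40 log units; beyond the scatter) from compound 3 to compound 4, 120-fold (2.08 log units) apart, beyond the scatter of two such steps. This shows that, in this series, the size of the step depends on the core carrying the change; it does not show which structural difference between the two cores is responsible, and two cores give no rule for predicting the step on a third.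

From the compounds shown here alone, it remains open whether the large step on the core of compound 3 needs both chlorines, or whether a 3-chlorophenyl or a 3,5-dimethylphenyl on the same nitrogen would give a step of similar size. Going by these compounds, it also remains open how far the number for compound 4 depends on the phenyl at the end of the amide chain, for example if a pyridine or a morpholine took its place on this core.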